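Methyl removal on the amine-bearing chain carbon

This account rests on a few compounds, and the source may have more. Where it says the series, first, only, none or still open, it means among the compounds named here.

Three compounds of this sulfonamide series carry measured values. Compound 1 `CCC(Nc1ccc(S(=O)(=O)Nc2nccs2)cc1Cl)c1ccccc1` gives 50 nM in an assay on HEK293 cells for inhibition of SCN8A/SCN1B (Homo sapiens), read by patch clamp, with a stated time of 20 min; on this read-out lower numbers stand for stronger inhibition and higher numbers for weaker inhibition. Compound 2 `CC(Nc1ccc(S(=O)(=O)Nc2nccs2)cc1Cl)c1ccccc1` gives 100 nM in this assay. The difference between them is hydrogen in place of methyl on a saturated chain carbon, two bonds along the chain from an aromatic carbon and a nitrogen on an aromatic ring, and the step is a 2.0-fold higher number from compound 1 to compound 2 (0.30 log units; within the scatter). Compound 3 `C[C@H](Nc1cc(F)c(S(=O)(=O)Nc2cscn2)cc1Cl)c1cc(F)ccc1F` gives 119 nM in this assay; it carries a different core, and the difference between the two cores is not broken down here. Against compound 2 its value sits within the scatter, against compound 1 beyond it.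

Compound 4 `O=S(=O)(Nc1cscn1)c1cc(Cl)c(NCc2cc(F)ccc2F)cc1F` is not yet measured. It differs from compound 3 by hydrogen in place of methyl on a saturated chain carbon bound to an aromatic carbon and a nitrogen on an aromatic ring. This is the same kind of change as that from compound 1 to compound 2, but not the same: there the methyl left a saturated chain carbon two bonds along the chain from an aromatic carbon and a nitrogen on an aromatic ring, here it leaves a saturated chain carbon bound to an aromatic carbon and a nitrogen on an aromatic ring.

Among the compounds with values here, only one instance of this change is measured, which gives a 2.0-fold higher number from compound 1 to compound 2 (0.30 log units; within the scatter), a step that lies within the scatter. Resting on that single step, the expectation for compound 4 is a step of a 2.0-fold higher number from compound 3 to compound 4 (0.30 log units; within the scatter) in this assay, with wide uncertainty because the change here sits one bond closer to the ring and the core differs. Compound 4 is thus estimated at 240 nM in this assay, between 100 nM and 700 nM.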

Compound 4, half-maximal inhibitory concentration in the SCN8A/SCN1B assay: 450 nM
For compound 4 the middle estimate is 1.9-fold (0.27 log units) below the measured one; the measured number falls inside the stated range.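

The same change gives the same direction on the second core: removing the methyl from the saturated chain carbon bound to an aromatic carbon and a nitrogen on an aromatic ring yields, in the SCN8A/SCN1B assay, a 3.8-fold higher number from compound 3 to compound 4 (0.58 log units; beyond the scatter); there compound 3 gives 119 nM and compound 4 gives 450 nM. Set beside the earlier instance, the two steps cannot be told apart, so the data allow the change to be carried from one core to the other with a similar effect on this read-out: the same change on two cores in the SCN8A/SCN1B assay, a 2.0-fold higher number (0.30 log units; within the scatter) from compound 1 to compound 2 and a 3.8-fold higher number (0.58 log units; beyond the scatter) from compound 3 to compound 4, 1.9-fold (0.28 log units) apart, within the scatter of two such steps. Within the data shown here, this does not show that the size of the step is fixed, since it rests on only two pairs in which the change sits at different places on different cores. In a physicochemical assay for lipophilicity, read by LC-MS, in phosphate buffer, measured as octanol-water partition, with a stated time of 1 h, at pH 7.4 (on this read-out higher numbers stand for higher lipophilicity and lower numbers for lower lipophilicity), compound 3 gives 3.5 and compound 4 gives 3.2; the pair, with a number 0.30 log units lower from compound 3 to compound 4 (within the scatter), offers no clear shift in that read-out to set beside the loss of inhibition.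

Open, from the compounds shown here alone, is whether the trend continues on the core of compound 2 with hydrogen in place of its remaining methyl, and whether an ethyl group on the core of compound 3 would give the gain that the core of compound 1 hints at. Also open, going by these compounds, is how a cyclopropyl ring or a hydroxymethyl group on this chain carbon would read on either core.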